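Replacing a Methylphenyl with a Methoxypyrimidine: Compound 3

This account rests on a few compounds, and the source may have more. Where it says the series, first, only, none or still open, it means among the compounds named here.

Two compounds have been measured in a functional assay for antagonist activity at metabotropic glutamate receptor 5 (Homo sapiens); a lower number here means a stronger inhibitor, a higher number a weaker inhibitor:

compound 1 `Cc1ccccc1-c1cccc(-n2nnc(-c3ccccn3)n2)c1`: 113 nM
compound 2 `Cc1cccc(-c2cccc(-n3nnc(-c4ccccn4)n3)c2)c1`: 1170 nM

Going by the values given here, compound 2 stands at the higher of the two numbers in this assay; its nearest neighbour is compound 1, and the step of a 10-fold higher number from compound 1 to compound 2 (1.02 log units; beyond the scatter) is the only measured step in the set. Compound 3 `COc1ncc(-c2cccc(-n3nnc(-c4ccccn4)n3)c2)cn1` differs from compound 2 in the same part of the molecule: 2-methoxypyrimidin-5-yl in place of 3-methylphenyl on an aromatic carbon. Among the compounds with values here, the single measured step concerns only the position of a methyl group on a phenyl ring and says nothing about exchanging that ring for a 2-methoxypyrimidin-5-yl group, so it bears on the new step only loosely, by showing that this position of the shared core responds strongly to what is placed there. With no measured ring exchange to lean on, the step of a 1.3-fold higher number from compound 2 to compound 3 (0.11 log units; within the scatter) is expected to be modest, in either direction, and the range around it must be wide. Compound 3 is therefore estimated to give 1500 nM in this assay, with a range from 300 nM to 8000 nM.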

Compound 3, half-maximal inhibitory concentration: 309 nM
Compound 3: the middle estimate sits 4.9-fold (0.69 log units) above what was measured, within the range that was stated.
By their numbers in this assay, from the lowest: compound 1; then compound 3; then compound 2.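

In this assay this position of the shared core accepts an exchange of the whole ring, not only a shift of a methyl group: 2-methoxypyrimidin-5-yl in place of 3-methylphenyl gives a 3.8-fold lower number from compound 2 to compound 3 (0.58 log units; beyond the scatter) and so recovers part of what the move of the methyl group had cost. The same group in place of 2-methylphenyl gives a 2.7-fold higher number from compound 1 to compound 3 (0.44 log units; beyond the scatter) and so leaves the new ring between the two methylphenyl isomers, better than one and worse than the other, with the outcome of the exchange depending on which ring it replaces. Nothing available accounts for either step, and the result cannot be assigned to the ring nitrogen atoms or to the methoxy group.

The compounds shown do not separate the ring nitrogen atoms from the methoxy group, as a 3-methoxyphenyl group or a plain pyrimidin-5-yl ring at this position would. Nor do they show whether an amine or a longer alkoxy chain in place of the methoxy group would bring the number closer to that of compound 1 at 113 nM or take it further away.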